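A few compounds are considered here, and "the series" means these few. Any claim that something is new, unique, unknown or untested is made for them only; others in the source may bear on it.

Measured so far in an assay on isolated protein for antagonist activity at Bile acid receptor (Homo sapiens), read by TR-FRET and LanthaScreen; a higher number here means a weaker inhibitor, a lower number a stronger inhibitor:
compound 1 `Cc1ccc2nc([C@H](CC3CCN(CC(C)C)CC3)N3C(=O)CN(c4ccc(Oc5ccccc5)cc4)C3=O)n(C)c2c1`: 16400 nM
compound 2 `Cc1ccc2nc([C@H](CC3CCN(C(=O)C(C)C)CC3)N3C(=O)CN(c4ccc(Oc5ccccc5)cc4)C3=O)n(C)c2c1`: 35 nM
compound 3 `Cc1ccc2nc([C@H](CC3CCN(C(=O)C4CCCC4)CC3)N3C(=O)CN(c4ccc(Oc5ccccc5)cc4)C3=O)n(C)c2c1`: 30 nM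

Compound 2 stands second highest of the three numbers in this assay; its nearest neighbour is compound 3, a step of a 1.2-fold lower number from compound 2 to compound 3 (0.07 log units; within the scatter), and the furthest is compound 1, a step of a 470-fold lower number from compound 1 to compound 2 (2.67 log units; beyond the scatter). Compound 4 `CC(C)C(=O)N1CCC(C[C@@H](c2nc3ccc(Cl)cc3n2C)N2C(=O)CN(c3ccc(Oc4ccccc4)cc3)C2=O)CC1` differs from compound 2 by chloro in place of methyl on an aromatic carbon. For the measured compounds named here, no measured step bears on this change: the large steps of a 470-fold lower number from compound 1 to compound 2 (2.67 log units; beyond the scatter) and a 550-fold lower number from compound 1 to compound 3 (2.74 log units; beyond the scatter) concern the substituent on the amine nitrogen in the ring, and the step of a 1.2-fold lower number from compound 2 to compound 3 (0.07 log units; within the scatter) lies within the scatter. With no guidance on direction, a step of no more than the scatter is expected. Compound 4 is therefore estimated at 35 nM, range 12 nM to 110 nM, meaning an expected no change at the digits printed from compound 2 to compound 4 (within the scatter).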

Compound 4, half-maximal inhibitory concentration: 130 nM
For compound 4 the middle estimate is 3.7-fold (0.57 log units) below the measured one; the whole stated range lies below it.
By their numbers in this assay, from the lowest: compounds 3 and 2 (each within the scatter of the next); then compound 4; then compound 1.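

In this assay, the aromatic carbon that carries methyl in compound 1, compound 2 and compound 3 now has a measured change, with a 3.7-fold higher number from compound 2 to compound 4 (0.57 log units; beyond the scatter) as the result of placing chloro there. This position therefore responds beyond the scatter, even though the swap leaves the heavy-atom, donor and acceptor counts unchanged. Nothing available here gives a reason for the shift. Open questions are whether the step holds with cyclopentylcarbonyl on the ring nitrogen, as in compound 3, and how fluoro, methoxy or nitrile would read at this aromatic carbon.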